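The compounds below may be only part of what the source reports. "The series", "measured", "known", "first", "only" and "open" are said of these compounds alone.

In an ADME assay on HEK293 cells (Homo sapiens) for cytotoxicity, read by resazurin assay, with a stated time of 48 h (on this read-out higher numbers stand for lower toxicity in this test and lower numbers for higher toxicity in this test), compound 1 `O=S(=O)(Nc1ccc2oc(-c3ccccc3)nc2c1)c1cccc(C(F)(F)F)c1` gives only a limit, > 100000 nM. Compound 3 `O=S(=O)(Nc1ccc(-c2nc3ccccc3o2)cc1)c1cccs1` also gives only a limit, > 100000 nM. Among the measured compounds shown here, compound 2 `COc1cccc(S(=O)(=O)Nc2ccc3oc(-c4ccccc4)nc3c2)c1` gives 63000 nM, the only true number of the three, which makes it the natural starting point for a comparison.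

The next compound to consider is compound 4 `COc1ccc(S(=O)(=O)Nc2ccc3oc(-c4ccccc4)nc3c2)cc1`. In it, 4-methoxyphenyl stands in place of 3-methoxyphenyl on a sulfonyl sulfur, and the two compounds have the same atoms, joined differently: 4-methoxyphenyl in place of 3-methoxyphenyl on a sulfonyl sulfur.

For the measured compounds named here, only one measured step bears on this change, as it also alters the group on that sulfonyl sulfur: an at least 1.5-fold lower number from compound 1 to compound 2 (0.20 log units; that floor lies within the scatter). That step replaces trifluoromethyl with methoxy and does not move a group from one place to another, so it offers only weak guidance and suggests no direction.

The expected result in this assay is therefore no change beyond the scatter, with the estimated step being a 1.1-fold higher number from compound 2 to compound 4 (0.05 log units; within the scatter). The estimate for compound 4 is 70000 nM, with an expected range from 30000 nM to 100000 nM.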

Compound 4, half-maximal cytotoxic concentration: 91000 nM
Beside the measured number, compound 4's estimate is 1.3-fold (0.11 log units) below it; the measured number falls inside the stated range.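

Moving the methoxy group, with 4-methoxyphenyl in place of 3-methoxyphenyl on a sulfonyl sulfur, is the first step here that changes only where a group sits, and in this assay it gives a 1.4-fold higher number from compound 2 to compound 4 (0.16 log units; within the scatter), so the two arrangements cannot be told apart in this test. Compound 4 also joins compound 2 as a second true number rather than a limit, which gives a firmer comparison than the earlier step from a limit could. Any further rise would be hard to follow, because the read-out stops at its upper end: the limit of > 100000 nM in this assay, at which 2 of the 4 values shown sit.

Going by these compounds, it remains open whether an amine or a carboxylic acid in place of methoxy would move the number beyond the scatter. The same question applies to a longer chain such as ethoxy.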